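This account rests on a few compounds, and the source may have more. Where it says the series, first, only, none or still open, it means among the compounds named here.

Compound 1 `COc1cc(-c2cc(/C=C/C(=O)c3ccc(N)cc3)[nH]n2)cc(OC)c1OC` was tested in a functional assay on SK-MEL-2 cells (Homo sapiens) for cytotoxicity, read by sulforhodamine B assay, with a stated time of 48 h, tested at 1 uM (on this read-out higher numbers stand for a weaker effect at the one concentration tested and lower numbers for a stronger effect), where compound 1 gives 104%. Two related compounds share its core and differ only in the aryl group on the carbonyl carbon. Compound 2 `COc1ccc(C(=O)/C=C/c2cc(-c3cc(OC)c(OC)c(OC)c3)n[nH]2)cc1` gives 97% in this assay, and compound 3 `COc1cc(-c2cc(/C=C/C(=O)c3ccc(F)c(F)c3)[nH]n2)cc(OC)c1OC` gives 94%. The steps of a number 7 percentage points lower from compound 1 to compound 2 (within the scatter) and a number 10 percentage points lower from compound 1 to compound 3 (within the scatter), as well as a number 3 percentage points lower from compound 2 to compound 3 (within the scatter), are all within the scatter, so these three compounds cannot be told apart in this assay, and each shows only a weak effect at the one concentration tested.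

Compound 4 `COc1ccc(-c2cc(/C=C/C(=O)c3ccc(N)cc3)[nH]n2)cc1OC` differs from compound 1 in a single place: hydrogen in place of methoxy on an aromatic carbon. Going by the values given here, none of the measured steps touches this part of the molecule; all three alter the aryl group on the carbonyl carbon, and each stayed within the scatter. Among the compounds with values here, there is thus no measured step that bears directly on the change to compound 4. The expected step of a number 4 percentage points lower from compound 1 to compound 4 (within the scatter) is therefore none beyond the scatter. Compound 4 is estimated to give 100% in this assay, with a range from 88% to 112%.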

Compound 4, a percentage reported as activity, at one concentration (the size of the read-out at that concentration, not a potency): 102%
Compound 4: the middle estimate sits 2 percentage points below what was measured, and the stated range covers the measured number.
By their numbers in this assay, from the lowest: compounds 3, 2, 4 and 1 (each within the scatter of the next).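

Going by these compounds alone, the earlier steps all changed the aryl group on the carbonyl carbon, so this is the first measured change on the other aromatic ring of the shared core. Hydrogen in place of methoxy, on an aromatic carbon ortho to a methoxy group and meta to a large group, gives a step of a number 2 percentage points lower from compound 1 to compound 4 (within the scatter) in this assay, so removing this one methoxy group leaves no effect that this read-out can detect at the one concentration tested. Nothing available here offers an explanation for this result.

Going by these compounds, whether a hydroxy group, a chlorine atom or an ethoxy group on this carbon would give a step beyond the scatter remains open. On these data alone, it is also open whether the same removal would read alike with 3,4-difluorophenyl or 4-methoxyphenyl on the carbonyl carbon in place of 4-aminophenyl.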